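This account rests on a few compounds, and the source may have more. Where it says the series, first, only, none or still open, it means among the compounds named here.

Values in an in vitro functional assay on cells for agonist activity at Bombesin receptor subtype-3 (Mus musculus), read by luminescence and calcium flux (a lower number here means that less compound is needed, a higher number that more compound is needed for the effect), for the measured members of the series:

Compound 1 `O=C(O)c1ccccc1-c1ccc(CCc2ncc(CCC3CCCCC3)[nH]2)cc1`: 33 nM
Compound 2 `O=C(O)c1ccccc1-c1ccc(CCc2ncc(Cc3cccc(Cl)c3)[nH]2)cc1`: 31 nM
Compound 3 `O=C(O)c1ccccc1-c1ccc(CCc2ncc(CC3CCCCCC3)[nH]2)cc1`: 5.7 nM

Compound 3 gives the lowest number of the three. The steps that reach it are a 5.8-fold lower number from compound 1 to compound 3 (0.76 log units; beyond the scatter) and a 5.4-fold lower number from compound 2 to compound 3 (0.74 log units; beyond the scatter), both beyond the scatter, whereas a 1.1-fold lower number from compound 1 to compound 2 (0.03 log units; within the scatter) lies within it. So the cycloheptyl on the saturated chain carbon bound to the aromatic carbon sets compound 3 apart; the cyclohexylmethyl and the 3-chlorophenyl at the same place behave alike.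

Compound 4 `O=C(O)c1ccccc1-c1ccc(CCc2ncc(-c3ccccc3)[nH]2)cc1` differs from compound 3 as follows: phenyl in place of cycloheptylmethyl on an aromatic carbon. Both measured steps that bear on this position show that replacing the cycloheptyl by another group costs a modest step, and compound 4 goes further still, dropping the chain carbon and the seven-membered ring together. For the measured compounds named here, no measured pair shows a phenyl attached straight to the aromatic carbon, so the size is uncertain. Taking compound 2 as the closest reference, a number in the region of compound 1 and compound 2 or somewhat higher is expected, meaning a 12-fold higher number from compound 3 to compound 4 (1.09 log units; beyond the scatter). The estimate for compound 4 in this assay is 70 nM, with a range of 20 nM to 300 nM.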

Compound 4, half-maximal effective concentration: 872 nM
For compound 4 the middle estimate is 12-fold (1.10 log units) below the measured one; measured number above the stated range.
By their numbers in this assay, from the lowest: compound 3; then compounds 2 and 1 (each within the scatter of the next); then compound 4.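

In this assay, a phenyl set directly on the aromatic carbon of the five-membered aromatic ring with 2 nitrogen is far less well tolerated than any of the earlier groups (a 150-fold higher number from compound 3 to compound 4 (2.18 log units; beyond the scatter); a 28-fold higher number from compound 2 to compound 4 (1.45 log units; beyond the scatter); a 26-fold higher number from compound 1 to compound 4 (1.42 log units; beyond the scatter)). All three steps are large, whereas the earlier groups, each joined through a saturated chain carbon, differed by modest steps at most, so this position proves far more sensitive than those compounds showed. Compound 2 also carries an aromatic ring on a chain carbon and stays within the scatter of compound 1, so an aromatic ring at this place does not by itself go with the high number, although the step to compound 4 removes the chain carbon and the chlorine together, and nothing available explains the size of the loss.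

Still open, as far as these compounds go, is whether benzyl, with the chain carbon kept and the chlorine gone, stays near compound 2 or moves towards compound 4. Equally open, from the compounds shown here alone, is whether cycloheptyl or 3-chlorophenyl attached straight to the aromatic carbon carries the same penalty as phenyl, which would place the sensitivity on the chain carbon rather than on the ring type.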